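Chloro to Methoxy: Expected Effect on Cell Toxicity

The source may hold more compounds than are shown below. What is called first, only, known or untested is meant among the compounds shown, and "the series" means these compounds.

Of the compounds shown here, three have been tested in a functional assay on Ehrlich cells (Mus musculus) for cytotoxicity, read by trypan blue exclusion, with a stated time of 2 h, tested at 10 ug/mL; on this read-out lower numbers stand for a stronger effect and higher numbers for a weaker effect at the one concentration tested. Compound 1 `CC(=O)N(C(C)=O)c1c(C#N)[n+]([O-])c2cc(Cl)ccc2[n+]1[O-]` gives 83.9%. Compound 2 `CCOc1ccc(NCc2nc3cc(OC)ccc3[n+]([O-])c2-c2ccccc2)cc1` gives 96.3%. Compound 3 `Cc1c(C(=O)N=[N+]=[N-])[n+]([O-])c2cc(Cl)ccc2[n+]1[O-]` gives 98%, the highest of the three numbers, which on this read-out means the weakest effect. Its nearest neighbour is compound 2, whose number is lower by an amount within the usual scatter, so the two cannot be told apart. Its furthest neighbour is compound 1, whose number is lower by an amount beyond the scatter, so compound 1 shows a clearly stronger effect than compound 3 at the concentration tested.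

Compound 4 `COc1ccc2c(c1)[n+]([O-])c(C(=O)N=[N+]=[N-])c(C)[n+]2[O-]` has not yet been measured. It differs from compound 3 in one place: methoxy in place of chloro on an aromatic carbon. Going by the values given here, no pair of measured compounds differs by exactly this change, so there is no measured step to lean on. Compound 2 also carries a methoxy on its core and gives 96.3%, a number near that of compound 3. The step of a number 2 percentage points lower from compound 3 to compound 4 (within the scatter) is therefore expected to be small, in no definite direction, and not beyond the scatter. Compound 4 is expected to give about 96%, most likely between 85% and 100%.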

Compound 4, a percentage reported as activity, at one concentration (the size of the read-out at that concentration, not a potency): 83.9%
For compound 4 the middle estimate is 12.1 percentage points above the measured one; the whole stated range lies above it.
By their numbers in this assay, from the lowest: compounds 1 and 4 (each within the scatter of the next); then compounds 2 and 3 (each within the scatter of the next).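

In this assay methoxy in place of chloro on an aromatic carbon of the six-membered ring of carbon only gives a number 14.1 percentage points lower from compound 3 to compound 4 (beyond the scatter) and so shows a clearly stronger effect at the one concentration tested. Going by these compounds alone, this is the first single change that can be read directly in this set, and it shows that the group on this carbon matters to the read-out, with the rest of the molecule unchanged. Nothing available explains why the swap has this effect, so the step stands as an observation only.

The compounds shown leave open whether this step belongs to methoxy specifically or would also appear with another group on the same carbon, such as an amine, a hydroxyl or a fluorine atom. Within the data shown here, they also leave open whether the same swap would act in the same way in a different compound, as this single pair is the only example, and whether the step would hold at other concentrations, as one concentration gives the size of an effect and not a potency.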